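Replacing the 2-acetoxypropyl chain of compound 3

The compounds below may be only part of what the source reports. "The series", "measured", "known", "first", "only" and "open" are said of these compounds alone.

Measured so far in a functional assay on DU-145 cells (Homo sapiens) for cytotoxicity, read by MTT assay; a higher number here means a weaker inhibitor, a lower number a stronger inhibitor
- Compound 1 `CC(=O)OCCC(=O)O[C@H](CC=C(C)C)C1=CC(=O)c2c(O)ccc(O)c2C1=O` gives 15700 nM
- Compound 2 `CC(=O)OCCO[C@H](CC=C(C)C)C1=CC(=O)c2c(O)ccc(O)c2C1=O` gives 15500 nM
- Compound 3 `CC(=O)OC(C)CO[C@H](CC=C(C)C)C1=CC(=O)c2c(O)ccc(O)c2C1=O` gives 16600 nM

Compound 3 at 16600 nM stands level with the other two, as the data show a 1.1-fold higher number from compound 1 to compound 3 (0.02 log units; within the scatter) and a 1.1-fold higher number from compound 2 to compound 3 (0.03 log units; within the scatter) on this read-out.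

The next step leads to compound 4 `CCC(C)(O)CC(=O)O[C@H](CC=C(C)C)C1=CC(=O)c2c(O)ccc(O)c2C1=O` with (2-hydroxy-2-methylbutyl)carbonyl in place of 2-acetoxypropyl on an oxygen on a saturated carbon, counted in full as (2-hydroxy-2-methylbutyl)carbonyl in place of 2-acetoxypropyl on an oxygen on a saturated carbon here.

Two measured steps already exchanged the group on such an oxygen, and they gave a 1.0-fold lower number from compound 1 to compound 2 (0.01 log units; within the scatter) and a 1.1-fold higher number from compound 1 to compound 3 (0.02 log units; within the scatter) in turn. Compound 4 resembles compound 1 in carrying a carbonyl-joined chain there, and compound 1 gives 15700 nM in this assay as well. Among the measured compounds shown here, no measured compound carries the 2-hydroxy-2-methylbutyl chain, so that part of the change is untested, and the range is kept wide.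

No shift beyond the scatter is expected, and the estimate is a 1.3-fold lower number from compound 3 to compound 4 (0.11 log units; within the scatter) in size.

For compound 4 the expected value is 13000 nM with an estimated range from 5000 nM to 28000 nM in this assay.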

Compound 4, half-maximal inhibitory concentration: 16000 nM
For compound 4 the middle estimate is 1.2-fold (0.09 log units) below the measured one; low and high end bracket the measured number.
By their numbers in this assay, from the lowest: compounds 2, 1, 4 and 3 (each within the scatter of the next).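

In this assay, putting (2-hydroxy-2-methylbutyl)carbonyl in place of 2-acetoxypropyl on an oxygen on a saturated carbon brings in a hydrogen-bond donor where the leaving group has none, yet the result stays within the scatter (a 1.0-fold lower number from compound 3 to compound 4 (0.02 log units; within the scatter)). The other two comparisons read the same (a 1.0-fold higher number from compound 2 to compound 4 (0.01 log units; within the scatter); a 1.0-fold higher number from compound 1 to compound 4 (0.01 log units; within the scatter)), so all four chains shown on this oxygen give level numbers, whether joined through a carbonyl or not. No measurement here explains this flat read-out.

Going by these compounds, whether a chain carrying an amine or a carboxylic acid, or a much longer chain, on this oxygen would move the number beyond the scatter remains open. On these data alone, all four compounds keep the shared core, so the effect of any change there also remains open.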